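The source may hold more compounds than are shown below. What is called first, only, known or untested is meant among the compounds shown, and "the series" means these compounds.

In a functional assay on MDA-MB-231 cells (Homo sapiens) for inhibition (on this read-out lower numbers stand for stronger inhibition and higher numbers for weaker inhibition), compound 1 `CC(C)c1ccc(N2C(=O)C=CC2OCC(F)(F)F)cc1` gives 6640 nM. For the measured compounds named here, compound 3 `O=C1C=CC(OCC(F)(F)F)N1c1cc(F)cc(F)c1` gives 7840 nM in this assay, a number that sits within the scatter of the one for compound 1, so the two cannot be told apart. Compound 2 `CC(C)NC1CC(=O)N(c2ccc(F)c(Cl)c2)C1OCC(F)(F)F` reaches only a limit of this assay, > 100000 nM, and no number. Compound 4 `CCc1ccc(N2C(=O)C=CC2OCC(F)(F)F)cc1` differs from compound 1 in one place: hydrogen in place of methyl on a saturated chain carbon bound to an aromatic carbon and a saturated chain carbon, which turns an isopropyl into an ethyl. Going by the values given here, no pair of measured compounds shows the effect of such a small trim on a saturated chain, so the expectation rests on the change being slight. The step from compound 1 to compound 4 is expected to be a 1.2-fold higher number from compound 1 to compound 4 (0.08 log units; within the scatter), no more than the scatter. Compound 4 is therefore estimated at 8000 nM in this assay, between 3500 nM and 20000 nM.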

Compound 4, half-maximal inhibitory concentration: 7840 nM
Compound 4: middle estimate off by 1.0-fold (0.01 log units), on the high side; measured number inside the range.
By their numbers in this assay, from the lowest: compounds 1, 3 and 4 (each within the scatter of the next). At a limit, above all of these: compound 2.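

Trimming isopropyl to ethyl gives a 1.2-fold higher number from compound 1 to compound 4 (0.07 log units; within the scatter) in this assay and so this saturated chain carbon, bound to an aromatic carbon and a saturated chain carbon, can lose a methyl without a readable change. For the compounds shown here, the earlier compounds held no pair differing in one place, so this is the first direct reading of a single change. Nothing measured here bears on the reason for this result.

The compounds shown do not tell whether a longer chain or an amine in place of the isopropyl would move the number beyond the scatter.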